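A few compounds are considered here, and "the series" means these few. Any claim that something is new, unique, unknown or untested is made for them only; others in the source may bear on it.

In a functional assay on MOLT-4 cells (Homo sapiens) for antiproliferative activity, read by cell counting, with a stated time of 2 days (a lower number here means a stronger inhibitor, a higher number a weaker inhibitor), three related compounds have been measured. Compound 1 `COc1cc(C(=O)c2sc(Nc3ccccc3)nc2N)cc(OC)c1OC` gives 6 nM and compound 3 `COc1ccc(Nc2nc(N)c(C(=O)c3ccccc3)s2)cc1` gives 230 nM. Compound 2 `COc1ccc(C(=O)c2sc(Nc3ccccc3)nc2N)cc1OC` gives 5500 nM, the highest number of the three and well beyond the scatter from both others.

Compound 4 `COc1ccc(Nc2nc(N)c(C(=O)c3ccc(OC)c(OC)c3)s2)cc1` keeps all of compound 2 but for one change, methoxy in place of hydrogen on an aromatic carbon, which turns anilino into (4-methoxyphenyl)amino. Among the compounds with values here, the only measured single-place step, a 920-fold higher number from compound 1 to compound 2 (2.96 log units; beyond the scatter), is large, but it concerns a methoxy on the other aromatic ring, so it does not transfer to this change in size. Compound 2 and compound 3 differ in more than one place, so their gap settles little on its own, yet compound 3 reaches 230 nM with the (4-methoxyphenyl)amino group in place. A moderate lowering of the number, not a large one, is therefore expected, with a 3.7-fold lower number from compound 2 to compound 4 (0.56 log units; beyond the scatter) as the estimated step. For compound 4 the expected value is 1500 nM, with an estimated range from 250 nM to 8000 nM.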

Compound 4, half-maximal inhibitory concentration: 37 nM
The estimate for compound 4 lay 41-fold (1.61 log units) above the measured number; the whole stated range lies above it.
By their numbers in this assay, from the lowest: compound 1; then compound 4; then compound 3; then compound 2.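

In this assay, the change to (4-methoxyphenyl)amino gives a 150-fold lower number from compound 2 to compound 4 (2.17 log units; beyond the scatter), so the anilino ring, on which compounds 1 and 2 carry no substituent, responds strongly to a methoxy para to a large group. The step is printed as large, as is a 920-fold higher number from compound 1 to compound 2 (2.96 log units; beyond the scatter) on the other aromatic ring, so in both single-place pairs a methoxy in place of hydrogen goes with the lower number. Nothing given here accounts for the size of the step at this position.

The compounds shown leave open whether a methyl, an ethoxy, a chlorine or a hydroxy at this place would do the same as methoxy. They also leave open whether (4-methoxyphenyl)amino would lower the number as far on the core of compound 1, which already reaches 6 nM with its plain anilino group.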